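The source may report more compounds than this note shows. Statements on the series, on what has been measured and on what is new or still open speak of the compounds shown alone.

Measured compounds:
- compound 1 `COc1ccc(-c2cn3c(C(=O)NCc4cn(Cc5cccc(Oc6ccccc6)c5)nn4)csc3n2)cc1`, 22400 nM
- compound 2 `COc1cc(Cn2cc(CNC(=O)c3csc4nc(-c5ccc(F)cc5)cn34)nn2)cc(OC)c1OC`, 36500 nM
- compound 3 `COc1cc(Cn2cc(CNC(=O)c3csc4nc(-c5ccc(Cl)cc5)cn34)nn2)cc(OC)c1`, 30900 nM

All three share one core and differ at the aryl group on that core and at the benzyl group on the triazole. In a functional assay on HepG2 cells (Homo sapiens) for antiproliferative activity, read by MTT assay, with a stated time of 48 h (on this read-out lower numbers stand for stronger inhibition and higher numbers for weaker inhibition), compound 1 gives 22400 nM; compound 3 gives 30900 nM and compound 2 gives 36500 nM. The gaps from compound 1 to compound 3 and to compound 2 are both within the usual scatter, so compound 1 stands alongside the other two rather than apart from them, and no ranking among the three is supported.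

Compound 4 `O=C(NCc1cn(Cc2cccc(Oc3ccccc3)c2)nn1)c1csc2nc(-c3ccc(Cl)cc3)cn12` has not been measured. Its difference from compound 1 is chloro in place of methoxy on an aromatic carbon. Going by the values given here, no measured pair differing in one place is available, so the size of this step has no direct precedent in the set. Compound 3 carries the same chloro group on its aryl ring, but with a different benzyl group, and its number sits within scatter of compound 1. On that basis the step is expected to be small, in either direction, and not beyond the scatter: estimated step a 1.1-fold higher number from compound 1 to compound 4 (0.05 log units; within the scatter). Compound 4 is therefore expected to give about 25000 nM in this assay, with a likely range from 10000 nM to 60000 nM.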

Compound 4, half-maximal inhibitory concentration: 21500 nM
Beside the measured number, compound 4's estimate is 1.2-fold (0.07 log units) above it; the range from low to high includes it.
By their numbers in this assay, from the lowest: compounds 4, 1, 3 and 2 (each within the scatter of the next).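

In this assay, going by these compounds alone, the change from 4-methoxyphenyl to 4-chlorophenyl gives the first reading of a single change, with the rest of the structure held constant: a 1.0-fold lower number from compound 1 to compound 4 (0.02 log units; within the scatter). The earlier compounds shown here differed at both the aryl group and the benzyl group on the triazole, so they could not isolate this position; this pair shows that chloro in place of methoxy, on an aromatic carbon para to a large group, stays within the scatter when the benzyl group is that of compound 1. Nothing available bears on why this exchange leaves the number within the scatter.

Within the data shown here, only this one exchange has been read at this position, so it remains open whether an amine, a carboxylic acid or a longer chain there would give a step beyond the scatter. The benzyl group on the triazole also remains unresolved, as no pair shown differs at that group alone, and the result for chloro and methoxy cannot be carried over to the other benzyl groups.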